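Chloro in place of methyl on compound 1

The source may report more compounds than this note shows. Statements on the series, on what has been measured and on what is new or still open speak of the compounds shown alone.

Measured in an ADME assay on a cell-free system (plasma, Rattus norvegicus) for metabolic stability, read by LC-MS, with a stated time of 60 min, tested at 100 uM; a higher number here means that more of the compound is left, a lower number that less of the compound is left:
- compound 1 `Cc1cc(C(=O)O)ccc1OCCCCOc1ccc(C(=O)CC(C)C)c(O)c1C`: 100%
- compound 2 `Cc1c(OCCCCOCOc2ccc(C(=O)O)cc2)ccc(C(=O)CC2CCCC2)c1O`: 100%
- compound 3 `CCCC(=O)c1ccc(OCCCCOc2cc(C(=O)O)ccc2OC)c(C)c1O`: 78%

Compound 1 stands level with compound 2 at the top of these three numbers, while compound 3 lies lower, beyond the scatter. Compound 4 `Cc1c(OCCCCOc2ccc(C(=O)O)cc2Cl)ccc(C(=O)CC(C)C)c1O` is the next to be read. It differs from compound 1 by chloro in place of methyl on an aromatic carbon. Among the measured compounds shown here, no measured pair isolates this change, so the data give no direct size for it. With compound 1 at 100% as the starting point, no step beyond the scatter is expected in this assay. The expected change is a number 5 percentage points lower from compound 1 to compound 4 (within the scatter). The estimate for compound 4 is 95%, with an expected range from 78% to 100%.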

Compound 4, percent of the compound remaining: 123%
Compound 4: middle estimate off by 28 percentage points, on the low side; the whole stated range lies below it.
By their numbers in this assay, from the lowest: compound 3; then compounds 1 and 2 (each within the scatter of the next); then compound 4.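

In this assay, among the compounds shown here, chloro in place of methyl on an aromatic carbon, ortho to a large group and meta to a carboxy group, gives a number 23 percentage points higher from compound 1 to compound 4 (beyond the scatter), the first step that isolates a single place. The change from 4-carboxy-2-methylphenyl to 4-carboxy-2-chlorophenyl alone is therefore enough to move this reading beyond the scatter. Nothing available explains the step.

As far as these compounds go, whether bromo or an amine on this carbon would move the number the same way remains open. So does whether the step carries over to the other compounds on the shared core.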